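The source may hold more compounds than are shown below. What is called first, only, known or untested is meant among the compounds shown, and "the series" means these compounds.

Compound 1 `O=C(C1CCC1)N1CCc2nc(C#Cc3ccccc3)sc2C1` carries a cyclobutylcarbonyl group on the amine nitrogen of its shared core. In an assay on HEK293 cells for positive allosteric modulation of metabotropic glutamate receptor 5 (Homo sapiens), read by FLIPR, with a stated time of 1 h (a lower number here means that less compound is needed, a higher number that more compound is needed for the effect), compound 1 gives > 10000 nM, which is a limit of the assay rather than a number, the point at which (the limit of > 10000 nM in this assay, at which 1 of the 3 values shown sits). Compound 2 `CC1CCC(C(=O)N2CCc3nc(C#Cc4ccccc4)sc3C2)CC1` gives 190 nM in this assay, and compound 3 `Cc1cccc(C(=O)N2CCc3nc(C#Cc4ccccc4)sc3C2)n1` gives 160 nM. The step of an at least 52-fold lower number from compound 1 to compound 2 (1.72 log units; beyond the scatter) and the step of an at least 62-fold lower number from compound 1 to compound 3 (1.79 log units; beyond the scatter) both show that exchanging the cyclobutyl on the carbonyl carbon for a larger group moves the number far downward, while a 1.2-fold lower number from compound 2 to compound 3 (0.07 log units; within the scatter) shows the two larger groups close together.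

Compound 4 `O=S(=O)(C1CC1)N1CCc2nc(C#Cc3ccccc3)sc2C1` differs from compound 1 by cyclopropylsulfonyl in place of cyclobutylcarbonyl on an amine nitrogen in a ring. The measured steps bear on this change only indirectly: they replace the cyclobutyl with larger groups and keep the carbonyl, whereas compound 4 keeps a small ring and replaces the carbonyl with a sulfonyl. Within the data shown here, none of the three measured compounds tests a sulfonyl or a cyclopropyl, so no step points to a large gain for compound 4, and its small ring sits closer to compound 1 than to compounds 2 and 3. The expected step is therefore a number no higher from compound 1 to compound 4 (the limit leaves the size open), with the result quite possibly again a limit. Compound 4 is estimated at 10000 nM, within a range from 2500 nM to 40000 nM.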

Compound 4, half-maximal effective concentration: > 10000 nM
Compound 4 ended at the assay's limit; the forecaster's own chance of this, stated with the estimate: 60%; the middle value sits exactly at the limit.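

In this assay, compound 1 and compound 4 both stand at a limit rather than at a number, so no step between them can be read: the limit of > 10000 nM in this assay, at which 2 of the 4 values shown sit.

The compounds shown leave open whether a sulfonyl carrying the 4-methylcyclohexyl group of compound 2 or the 6-methylpyridin-2-yl group of compound 3 would give a readable value.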